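Bromochromenone triazoles: sulfur-to-oxygen swap at the linker

The compounds below may be only part of what the source reports. "The series", "measured", "known", "first", "only" and "open" are said of these compounds alone.

Measured so far in a functional assay on MCF7 cells (Homo sapiens) for antiproliferative activity, read by MTT assay, with a stated time of 48 h; on this read-out lower numbers stand for stronger inhibition and higher numbers for weaker inhibition:
compound 1 `O=c1cc(-n2cc(-c3ccccc3)nn2)c2cc(Br)ccc2o1` gives 9450 nM
compound 2 `O=c1cc(-n2cc(CSc3ccccc3)nn2)c2cc(Br)ccc2o1` gives 36800 nM

Among the measured compounds shown here, compound 2 carries the higher of the two numbers; the one step recorded, a 3.9-fold higher number from compound 1 to compound 2 (0.59 log units; beyond the scatter), separates it from compound 1, and that step is beyond the scatter.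

Compound 3 `O=c1cc(-n2cc(COc3ccccc3)nn2)c2cc(Br)ccc2o1` is the next member. It differs from compound 2 by phenoxy in place of phenylsulfanyl on a saturated chain carbon bound to an aromatic carbon. For the measured compounds named here, no measured step touches this change: the single recorded step, a 3.9-fold higher number from compound 1 to compound 2 (0.59 log units; beyond the scatter), concerns the insertion of the (phenylsulfanyl)methyl linker, not the exchange of sulfur for oxygen within it, so it gives direction only loosely. With the phenyl ring kept at the same distance from the core, the expectation is a number close to that of compound 2, with no step beyond the scatter in either direction; the estimated step is a 1.2-fold lower number from compound 2 to compound 3 (0.09 log units; within the scatter). Compound 3 is therefore expected to give 30000 nM in this assay, within 10000 nM to 90000 nM.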

Compound 3, half-maximal inhibitory concentration: 1720 nM
Estimate against measurement, compound 3: 17-fold (1.24 log units) above; measured number below the stated range.
By their numbers in this assay, from the lowest: compound 3; then compound 1; then compound 2.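

Within this assay the exchange of sulfur for oxygen in the linker gives a 21-fold lower number from compound 2 to compound 3 (1.33 log units; beyond the scatter) even though phenoxy and phenylsulfanyl match in heavy atoms, in their aromatic ring and in counted hydrogen-bond acceptors. The linker therefore does not by itself raise the number: phenoxymethyl in place of phenyl gives a 5.5-fold lower number from compound 1 to compound 3 (0.74 log units; beyond the scatter) while (phenylsulfanyl)methyl gave a 3.9-fold higher number from compound 1 to compound 2 (0.59 log units; beyond the scatter) in the opposite direction. Compound 3 now has the lowest number of the three, so the identity of the linking atom matters at this position at least as much as the presence of a linker.

On these data alone, whether an amine in place of the phenoxy oxygen or a longer chain ahead of the phenyl ring would keep this lower number remains open. Nothing available explains the gap between the sulfur and oxygen linkers.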